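Amide variation on a shared thioether core: clearance notes

The source may report more compounds than this note shows. Statements on the series, on what has been measured and on what is new or still open speak of the compounds shown alone.

Measured so far in an ADME assay on microsomes from liver (Mus musculus) for metabolic stability, read by LC-MS, using NADPH, with a stated time of 45 min, tested at 0.5 uM; on this read-out lower numbers stand for slow clearance and higher numbers for fast clearance:
- compound 1 `COc1ccc2oc(SCCC(=O)N3CCCC3)nc2c1`: 198 mL/min/g
- compound 2 `O=C(CCSc1nc2cc(Cl)ccc2o1)NC1CCCC1`: "not determined" (no result reported)

In this assay compound 1 gives 198 mL/min/g, which sits at the fast-clearance end of the read-out. Compound 2 stands nowhere on these numbers: in this assay compound 2 returns "not determined" (no result reported), so it offers no footing against which a step could be sized or given a direction.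

Compound 3 `O=C(CCSc1nc2cc(Cl)ccc2o1)N1CCCCC1` differs from compound 2 by piperidin-1-yl in place of cyclopentylamino on a carbonyl carbon. For the measured compounds named here, because compound 2 has no result in this assay, no step between compound 2 and compound 3 can be expected in either direction or called within or beyond the scatter; the change is recorded, not measured. The only anchor for the series in this assay is compound 1, whose fast clearance is taken as the working reference because compound 1 gives 198 mL/min/g.

Compound 3 is therefore expected to clear fast as well, estimated at 150 mL/min/g with a range of 50 mL/min/g to 450 mL/min/g.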

Compound 3, intrinsic clearance in a liver preparation (reported as CLH), per the amount of preparation that the assay uses: 128 mL/min/g
Estimate against measurement, compound 3: 1.2-fold (0.07 log units) above; the measured number falls inside the stated range.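

In this assay compound 2 returns "not determined" (no result reported) and compound 3 gives 128 mL/min/g as its value, so no step can be read between compound 2 and compound 3. No evidence bears on this result. Still open, going by these compounds, is how piperidin-1-yl and cyclopentylamino compare for clearance on this shared core.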